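A few compounds are considered here, and "the series" means these few. Any claim that something is new, unique, unknown or untested is made for them only; others in the source may bear on it.

For the measured compounds named here, compound 2 `COc1ccccc1Cc1cn(C2CC2)c2c(F)c(-c3cc(C)nc(C)c3)c(F)cc2c1=O` gives 37000 nM in a functional assay on P388 cells (Mus musculus) for cytotoxicity (on this read-out higher numbers stand for weaker inhibition and lower numbers for stronger inhibition), the highest of the two numbers so far; compound 1 `Cc1cc(-c2c(F)cc3c(=O)c(Cc4cccc(O)c4O)cn(C4CC4)c3c2F)cc(C)n1` gives 880 nM. Going by the values given here, only one measured step exists, a 42-fold higher number from compound 1 to compound 2 (1.62 log units; beyond the scatter), and it is the one that bears on the next change. Compound 3 `Cc1cc(-c2c(F)cc3c(=O)c(Cc4ccccc4N)cn(C4CC4)c3c2F)cc(C)n1` carries amino in place of methoxy on an aromatic carbon, so one hydrogen-bond donor returns where compound 2 has none, though not the two hydroxyls of compound 1. A move back toward compound 1, smaller than the measured step, is expected. Compound 3 is estimated at 10000 nM (range 3000 nM to 40000 nM), that is a 3.7-fold lower number from compound 2 to compound 3 (0.57 log units; beyond the scatter) expected.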

Compound 3, half-maximal inhibitory concentration: 2100 nM
The estimate for compound 3 lay 4.8-fold (0.68 log units) above the measured number; measured number below the stated range.
By their numbers in this assay, from the lowest: compound 1; then compound 3; then compound 2.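

In this assay, amino in place of methoxy on this aromatic carbon gives an 18-fold lower number from compound 2 to compound 3 (1.25 log units; beyond the scatter), so one amino group recovers most of the ground lost with 2-methoxyphenyl. The 2-aminophenyl group still falls modestly short of 2,3-dihydroxyphenyl, with a 2.4-fold higher number from compound 1 to compound 3 (0.38 log units; beyond the scatter), so the two hydroxyls are not fully matched. No data here account for either step. Open, on these data alone, is how a single hydroxyl or a dimethylamino group on this carbon would compare with amino, which would test whether the hydrogens on the amino nitrogen matter.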